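Swapping naphthalen-2-yl for 4-chlorophenyl on a shared core

A few compounds are considered here, and "the series" means these few. Any claim that something is new, unique, unknown or untested is made for them only; others in the source may bear on it.

Measured so far in a functional assay on aorta (strain Wistar) for inhibition, with Thoracic aorta (Rattus norvegicus) as the target; on this read-out lower numbers stand for stronger inhibition and higher numbers for weaker inhibition:
- compound 1, `COc1nc(-c2cc3ccccc3o2)cc(-c2cccc3ccccc23)c1C#N`: 359000 nM
- compound 2, `COc1nc(-c2cc3ccccc3o2)cc(-c2ccc3ccccc3c2)c1C#N`: 320000 nM
- compound 3, `CCOc1nc(-c2cc3ccccc3o2)cc(-c2ccc3ccccc3c2)c1C#N`: 423000 nM

All three compounds share one core and differ only in the group at one aromatic carbon and in the alkoxy group. Compound 3 sits at the upper end of the three numbers, but its gaps to compound 1 and compound 2 both fall within the scatter, so the three are not told apart in this assay. Within the data shown here, the one step measured between neighbours, a 1.3-fold higher number from compound 2 to compound 3 (0.12 log units; within the scatter), touches only the alkoxy group and left the number essentially unchanged.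

Compound 4, `CCOc1nc(-c2cc3ccccc3o2)cc(-c2ccc(Cl)cc2)c1C#N`, has not been measured. It differs from compound 3 by 4-chlorophenyl in place of naphthalen-2-yl on an aromatic carbon. No measured step bears on this change: compound 1 and compound 2 carry the two naphthyl groups and give numbers within the scatter of each other, and nothing shown replaces a naphthyl with a chlorinated phenyl. Among the measured compounds shown here, with no step to lean on, the expectation is a number close to compound 3, and the step from compound 3 to compound 4 is estimated as a 1.1-fold lower number from compound 3 to compound 4 (0.02 log units; within the scatter). For compound 4 the estimate in this assay is 400000 nM, with a range from 150000 nM to 1000000 nM.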

Compound 4, half-maximal inhibitory concentration: 221000 nM
The estimate for compound 4 lay 1.8-fold (0.26 log units) above the measured number; measured number inside the range.
By their numbers in this assay, from the lowest: compounds 4, 2, 1 and 3 (each within the scatter of the next).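

In this assay, this aromatic carbon, opposite the ring nitrogen, now has a swap that can be read directly: a 1.9-fold lower number from compound 3 to compound 4 (0.28 log units; within the scatter), so compound 3 and compound 4 are not told apart. The earlier compounds shown here varied only the naphthyl group and the alkoxy group, whereas this step shows that the number stays within the scatter even when naphthalen-2-yl, with 2 six-membered aromatic rings, gives way to 4-chlorophenyl, with one such ring and a chlorine. Nothing given here offers a measured explanation for this result.

The compounds shown leave open whether a quite different group on this carbon, such as an amine or a carboxylic acid, would give a number clearly apart from that of compound 3. Also open, on these data alone, is what the chlorine itself contributes, a question that a plain phenyl group on the same carbon could answer when set beside compound 4.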